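The compounds below may be only part of what the source reports. "The series", "measured", "known", "first", "only" and "open" are said of these compounds alone.

Values measured in an ADME assay on TZM cells (Homo sapiens) for cytotoxicity, read by XTT assay, with a stated time of 4 days; on this read-out lower numbers stand for higher toxicity in this test and higher numbers for lower toxicity in this test:

- Compound 1 `Cc1cc(N)cc(C)c1Oc1cc(Nc2ccc(C#N)cc2)c(N)cc1C(F)(F)F`: 15800 nM
- Compound 2 `CC(=O)CCc1cc(C)c(Oc2cc(Nc3ccc(C#N)cc3)c(N)cc2C(F)(F)F)c(C)c1`: 11100 nM
- Compound 3 `CNC(=O)c1cc(N)c(Nc2ccc(C#N)cc2)cc1Oc1c(C)cc(CCC#N)cc1C`: > 9100 nM (a limit)

Compound 3 has no number of its own in this assay. Its entry of > 9100 nM is a limit of the assay.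

Compound 4 `Cc1cc(CCC#N)cc(C)c1Oc1cc(Nc2ccc(C#N)cc2)c(N)cc1S(N)(=O)=O` has not yet been measured. It differs from compound 3 by sulfamoyl in place of methylcarbamoyl on an aromatic carbon.

Going by the values given here, no measured step touches this place. Among the compounds with values here, the only step available is 2-acetylethyl in place of amino on an aromatic carbon, a 1.4-fold lower number from compound 1 to compound 2 (0.15 log units; within the scatter). It concerns a different group and bears on the present change only indirectly, as the one case where a single change could be followed in this assay. On that slender basis, no step beyond the scatter is expected in this assay, in either direction, although the limit for compound 3 leaves the starting point open.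

For compound 4 the estimated value is 12000 nM, with an expected range of 5000 nM to 30000 nM. This estimate means an expected step that the limit leaves unreadable from compound 3 to compound 4.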

Compound 4, half-maximal cytotoxic concentration: 11100 nM
Estimate against measurement, compound 4: 1.1-fold (0.03 log units) above, within the range that was stated.
By their numbers in this assay, from the lowest: compounds 2, 4 and 1 (each within the scatter of the next).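

Going by these compounds alone, no step from compound 3 to compound 4 can be read in this assay, because compound 3 carries only a limit and no number of its own: the limit of > 9100 nM in this assay, at which 1 of the 4 values shown sits. The compounds shown leave open how far sulfamoyl in place of methylcarbamoyl on an aromatic carbon moves the number in this assay on its own.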